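The compounds below may be only part of what the source reports. "The series", "measured", "known", "first", "only" and "open" are said of these compounds alone.

Compound 2 `COc1ccc(C)cc1Cn1c(C(=O)NCC(C)(C)CO)cc2cc(C#N)ccc21` in an in vitro ADME assay on microsomes from liver (Homo sapiens) for metabolic stability, in the presence of a further agent that is not named here (a higher number here means faster removal of the compound, a lower number slower removal), gives 23 mL.min-1.g-1. Among the compounds with values here, only one other compound is measured: compound 1 `CC(C)(CO)CNC(=O)c1cc2cc(C#N)ccc2n1Cc1cc(Cl)cc(Cl)c1` gives 22 mL.min-1.g-1, and the two numbers lie within the scatter of each other. Within the data shown here, the single measured step, a 1.0-fold higher number from compound 1 to compound 2 (0.02 log units; within the scatter), exchanged the aryl group on the saturated chain carbon bound to the aromatic nitrogen and left the number unmoved beyond the scatter. Compound 3 `Cc1ccc(C)c(Cn2c(C(=O)NCC(C)(C)CO)cc3cc(C#N)ccc32)c1` is not yet measured. Its difference from compound 2 is methyl in place of methoxy on an aromatic carbon. Among the measured compounds shown here, no measured step touches this position or this exchange of methyl for methoxy, so nothing measured speaks directly to it; the one step available, elsewhere in the molecule, gave no shift. Absent any indication of movement, no step beyond the scatter is expected. Compound 3 is estimated at 23 mL.min-1.g-1, with a range of 11 mL.min-1.g-1 to 46 mL.min-1.g-1. The step of no change at the digits printed from compound 2 to compound 3 (within the scatter) is therefore expected to stay within the scatter.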

Compound 3, intrinsic clearance in microsomes: 29 mL.min-1.g-1
Estimate against measurement, compound 3: 1.3-fold (0.10 log units) below, within the range that was stated.
By their numbers in this assay, from the lowest: compounds 1, 2 and 3 (each within the scatter of the next).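

Methyl in place of methoxy on the aromatic carbon ortho to a large group now has its own reading in this assay, a 1.3-fold higher number from compound 2 to compound 3 (0.10 log units; within the scatter), so this assay does not separate the two groups at this position. The 2,5-dimethylphenyl and 3,5-dichlorophenyl groups are not separated either, with a 1.3-fold higher number from compound 1 to compound 3 (0.12 log units; within the scatter), and so all three aryl groups shown lie within the scatter of one another. No measured information is available to explain these readings.

As far as these compounds go, whether any group on this aromatic carbon can move the number beyond the scatter remains open, and an amine or a carboxylic acid there would be a sharper test than methyl or methoxy. From the compounds shown here alone, the amide side chain and the nitrile are the same in all three compounds, so the effect of a longer chain on the amide or of a carboxylic acid in place of the nitrile also remains unknown.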